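Swapping trifluoromethoxy for chloro on the shared core

This account rests on a few compounds, and the source may have more. Where it says the series, first, only, none or still open, it means among the compounds named here.

Within the data shown here, in a functional assay on NALM-6 cells (Homo sapiens) for cytotoxicity, read by luminescence and CellTiter-Glo, with a stated time of 3 days (a higher number here means a weaker inhibitor, a lower number a stronger inhibitor), compound 1 `O=C(Nc1ccc(OC(F)(F)F)cc1)c1cc(F)ccc1O` gives 1210 nM and compound 2 `O=C(Nc1ccc(OC(F)(F)F)c(Cl)c1)c1cc(F)ccc1O` gives 1000 nM, so compound 2 stands level with its only neighbour. Compound 3 `O=C(Nc1ccc(Cl)c(Cl)c1)c1cc(F)ccc1O` carries chloro in place of trifluoromethoxy on an aromatic carbon, ortho to a chloro group and para to a large group: chloro in place of trifluoromethoxy on an aromatic carbon. Among the measured compounds shown here, the one measured step, a 1.2-fold lower number from compound 1 to compound 2 (0.08 log units; within the scatter), is a different change, chloro in place of hydrogen, and offers only a weak guide. No shift beyond the scatter is therefore expected in this assay, and the estimated step is a 1.2-fold higher number from compound 2 to compound 3 (0.08 log units; within the scatter). Compound 3 is expected at 1200 nM, within an estimated range of 500 nM to 3000 nM.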

Compound 3, half-maximal inhibitory concentration: 1370 nM
Compound 3: middle estimate off by 1.1-fold (0.06 log units), on the low side; measured number inside the range.
By their numbers in this assay, from the lowest: compounds 2, 1 and 3 (each within the scatter of the next).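

In this assay, swapping trifluoromethoxy for chloro at this position, ortho to a chloro group, gives a 1.4-fold higher number from compound 2 to compound 3 (0.14 log units; within the scatter). Here chloro, with 1 heavy atom, stands in for trifluoromethoxy, with 5 heavy atoms, without a shift beyond the scatter, so trifluoromethoxy is not required at this position to stay in this range. No other evidence bears on this result. The compounds shown leave open whether an amine or a carboxylic acid at this position would move the number beyond the scatter.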